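Methoxy to methyl on the pyrimidine of compound 2

The compounds below may be only part of what the source reports. "The series", "measured", "known", "first", "only" and "open" are said of these compounds alone.

Two compounds of this series have numbers in a functional assay on the whole organism (strain L.) for inhibition, with Echinochloa crus-galli as the target, with a stated time of 72 h, tested at 10 mg/L; a higher number here means more inhibition of growth at the concentration tested, a lower number less inhibition of growth. Compound 1 `COc1cc(C)nc2n/c(=N/C(=O)c3c(-c4ccc(Cl)cc4Cl)noc3C)sn12` gives 30.9% in this assay. Compound 2 `COc1cc(SC)nc(NC(=S)NC(=O)c2c(-c3ccc(Cl)cc3Cl)noc2C)n1` gives 19.3% in this assay, the lower of the two numbers; compound 1 stands higher by a gap beyond the scatter. Going by the values given here, compound 1 and compound 2 differ in more than one place, so the two values show only that compound 2 is the weaker of the pair, not what any single change does.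

Compound 3 `CSc1cc(C)nc(NC(=S)NC(=O)c2c(-c3ccc(Cl)cc3Cl)noc2C)n1` is not yet measured. It differs from compound 2 by methyl in place of methoxy on an aromatic carbon. Among the compounds with values here, no pair that differs in one place has been measured, so nothing here tells how large a step of this kind is or in which direction it goes. The working expectation is therefore a step of no size beyond the scatter, with the estimated step from compound 2 to compound 3 being a number 2.7 percentage points higher from compound 2 to compound 3 (within the scatter) in this assay. Compound 3 is estimated at 22%, within a range from 8% to 40%.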

Compound 3, percent growth inhibition at one concentration: 27.4%
For compound 3 the middle estimate is 5.4 percentage points below the measured one; the measured number falls inside the stated range.
By their numbers in this assay, from the lowest: compounds 2, 3 and 1 (each within the scatter of the next, the first and the last beyond it).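

Going by these compounds alone, with methyl in place of methoxy on this aromatic carbon of the six-membered aromatic ring with 2 nitrogen, this assay gives a number 8.1 percentage points higher from compound 2 to compound 3 (within the scatter), the first step that can be read for one change alone. At this position, then, the substituent can go from the 2 heavy atoms of methoxy to the 1 heavy atom of methyl, and the hydrogen-bond acceptor of methoxy can go with it, without a step beyond the scatter, so methoxy is not needed here to hold the growth inhibition at this level. Nothing at hand offers a measured property that would bear on this step.

One step within the scatter gives neither a direction nor a size for this position, and it leaves open whether a group of another kind here, such as an amine, a hydroxyl or a longer chain like butoxy, would move the number beyond the scatter. Also open, from the compounds shown here alone, is whether the methylsulfanyl group, which stays the same in this pair, matters to the number, as does the effect of replacing it with a chlorine atom.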